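Iodo for bromo: one step measured, one expected

The source may hold more compounds than are shown below. What is called first, only, known or untested is meant among the compounds shown, and "the series" means these compounds.

Measured in a functional assay on HeLa cells (Homo sapiens) for antiproliferative activity, read by cell counting, with a stated time of 72 h; on this read-out higher numbers stand for weaker inhibition and lower numbers for stronger inhibition:
compound 1 `C#C[C@@]1(O)[C@@H](CO)O[C@@H](n2cc(Br)c3c(N)ncnc32)[C@@H]1O`, 93 nM
compound 2 `C#C[C@@]1(O)[C@@H](CO)O[C@@H](n2cc(I)c3c(N)ncnc32)[C@@H]1O`, 180 nM
compound 3 `C#C[C@@]1(O)[C@@H](CO)O[C@@H](n2cc(Br)c3c(Cl)ccnc32)[C@@H]1O`, 890 nM

Compound 4 `C#C[C@@]1(O)[C@@H](CO)O[C@@H](n2cc(I)c3c(Cl)ccnc32)[C@@H]1O` is not yet measured. The change from compound 3 to compound 4, (iodo in place of bromo on an aromatic carbon), is the same kind of change as that from compound 1 to compound 2, (iodo in place of bromo on an aromatic carbon); the two place descriptions agree word for word. That earlier change gave a 1.9-fold higher number from compound 1 to compound 2 (0.29 log units; within the scatter). The difference between the two cores, compound 1 against compound 3, is not broken down here; in this assay compound 3 stands beyond the scatter from both compound 1 and compound 2. For the measured compounds named here, only one instance of the change is measured, so the expectation for compound 4 rests on that single step. Compound 4 is expected to show a 1.8-fold higher number from compound 3 to compound 4 (0.25 log units; within the scatter), because the same kind of change gave a 1.9-fold higher number from compound 1 to compound 2 (0.29 log units; within the scatter). Compound 4 is estimated at 1600 nM, with a range of 600 nM to 4500 nM.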

Compound 4, half-maximal inhibitory concentration: 1100 nM
Beside the measured number, compound 4's estimate is 1.5-fold (0.16 log units) above it; low and high end bracket the measured number.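

In this assay, iodo in place of bromo gives a 1.2-fold higher number from compound 3 to compound 4 (0.09 log units; within the scatter), and this step agrees with the one measured on the other core: the same change on two cores in this assay, a 1.9-fold higher number (0.29 log units; within the scatter) from compound 1 to compound 2 and a 1.2-fold higher number (0.09 log units; within the scatter) from compound 3 to compound 4, 1.6-fold (0.19 log units) apart, within the scatter of two such steps. On these two pairs, the change carries from one core to the other without a detectable difference, and neither step can be told from the scatter. This does not establish a direction for the change, and two cores cannot show that it would carry to further cores in the series.

As far as these compounds go, whether a smaller or different group in that place, such as a methyl or a nitrile, would also leave the number unmoved remains open. Which part of the difference between the two cores matters also remains open.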